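Replacing Fluoro by an Amide on the Weakest Compound

The compounds below may be only part of what the source reports. "The series", "measured", "known", "first", "only" and "open" are said of these compounds alone.

A set of three compounds that share a core were tested in an assay for inhibition of serine/threonine-protein kinase PLK2 (Homo sapiens), read by FRET and Z'-LYTE, with a stated time of 1 h; on this read-out higher numbers stand for weaker inhibition and lower numbers for stronger inhibition. Compound 1 `CCCNS(=O)(=O)c1ccc(Nc2ncc3c(n2)N(c2ccn(C)n2)C(CC)C(=O)N3C)cc1` gives 190 nM, compound 2 `CC[C@@H]1C(=O)N(C)c2cnc(Nc3ccc(S(=O)(=O)NCCCO)cc3)nc2N1C1CCCC1` gives 8.16 nM, and compound 3 `CC[C@@H]1C(=O)N(C)c2cnc(-n3ccc4cc(F)ccc43)nc2N1C1CCCC1` gives 969 nM, the highest of the three numbers, standing beyond the scatter from both of the others. Compound 4 `CC[C@@H]1C(=O)N(C)c2cnc(-n3ccc4cc(C(=O)NCC(C)C)ccc43)nc2N1C1CCCC1` differs from compound 3 in one place: isobutylcarbamoyl in place of fluoro on an aromatic carbon. For the measured compounds named here, no measured pair shows a change of this kind, so its effect is not known from these data. A small step toward a lower number is expected, one that could still fall within the scatter, with the estimated step being a 1.6-fold lower number from compound 3 to compound 4 (0.21 log units; within the scatter). Compound 4 is therefore expected to give 600 nM, within a range from 120 nM to 3000 nM.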

Compound 4, half-maximal inhibitory concentration: 18.6 nM
Beside the measured number, compound 4's estimate is 32-fold (1.51 log units) above it, outside the stated range (below it).
By their numbers in this assay, from the lowest: compound 2; then compound 4; then compound 1; then compound 3.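

At this position on the six-membered aromatic ring, the change matters greatly in this assay: isobutylcarbamoyl in place of fluoro gives a 52-fold lower number from compound 3 to compound 4 (1.72 log units; beyond the scatter). The earlier compounds shown here held no change at this place, and this step shows that the much larger group, with its amide hydrogen and carbonyl, is accepted here and goes with far stronger inhibition. Nothing available explains the size of this step.

The compounds shown do not separate the contribution of the amide from that of the isobutyl chain. A carboxylic acid, or an amide carrying a methyl group, at this position would help tell them apart.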